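Ring nitrogen in the aryl piperazine group

The source may hold more compounds than are shown below. What is called first, only, known or untested is meant among the compounds shown, and "the series" means these compounds.

Compound 1 `COc1ccc(N2CCN([C@@H]3CN[C@H](C(=O)N4CCSC4)C3)CC2)cc1` gives 16.9 nM in an assay on a cell-free system (plasma) for inhibition of Dipeptidyl peptidase 4 (Rattus norvegicus), read by fluorescence; on this read-out lower numbers stand for stronger inhibition and higher numbers for weaker inhibition. Compound 2 `O=C([C@@H]1C[C@H](N2CCN(c3ccncc3)CC2)CN1)N1CCSC1` gives 3.9 nM. Compound 3 `O=C([C@@H]1C[C@H](N2CCN(c3ccc(Cl)cc3)CC2)CN1)N1CCSC1` gives 10.3 nM, the second highest of the three numbers; it sits near compound 1 and furthest from compound 2. Compound 4 `O=C([C@@H]1C[C@H](N2CCN(c3ccc(Cl)cn3)CC2)CN1)N1CCSC1` differs from compound 3 by 5-chloropyridin-2-yl in place of 4-chlorophenyl on an amine nitrogen in a ring. For the measured compounds named here, two measured steps bear on this change: a 4.3-fold lower number from compound 1 to compound 2 (0.64 log units; beyond the scatter), and a 2.6-fold higher number from compound 2 to compound 3 (0.42 log units; beyond the scatter). Both steps show that a ring nitrogen in the aryl group goes with a lower number, so a modest step downward beyond the scatter is expected for compound 4, namely a 2.1-fold lower number from compound 3 to compound 4 (0.31 log units; beyond the scatter). Compound 4 is therefore estimated at 5 nM, within a range from 2 nM to 12 nM.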

Compound 4, half-maximal inhibitory concentration: 3.1 nM
For compound 4 the middle estimate is 1.6-fold (0.21 log units) above the measured one, within the range that was stated.
By their numbers in this assay, from the lowest: compounds 4 and 2 (each within the scatter of the next); then compounds 3 and 1 (each within the scatter of the next).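

With the chloro group kept, a ring nitrogen in the aryl group still goes with a lower number in this assay (a 3.3-fold lower number from compound 3 to compound 4 (0.52 log units; beyond the scatter)), so the earlier trend now holds in a direct chlorinated pair. 5-Chloropyridin-2-yl and pyridin-4-yl cannot be separated (a 1.3-fold lower number from compound 2 to compound 4 (0.10 log units; within the scatter)), while the step from the methoxy compound is the largest at this position (a 5.5-fold lower number from compound 1 to compound 4 (0.74 log units; beyond the scatter)). No measurement shown explains these differences. Going by these compounds, the separate contributions of the chloro group and the place of the ring nitrogen remain open. Unsubstituted pyridin-2-yl, or a nitrile in place of chloro, would address this.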